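A few compounds are considered here, and "the series" means these few. Any claim that something is new, unique, unknown or untested is made for them only; others in the source may bear on it.

Measured so far:
compound 1 `CCN(c1nc(C)cc(N2CCC=C(c3ccccc3C)C2)n1)c1ccc(C(C)C)cc1SC` — 10 nM
compound 2 `CCN(c1nc(C)cc(N2CC=C(c3cccc(F)c3)CC2)n1)c1ccc(C(C)C)cc1Br` — 22.1 nM

Within the data shown here, only two compounds have numbers in an assay on membranes from Cerebral cortex for inhibition of Corticotropin releasing factor receptor (Rattus norvegicus), read by radioligand binding; on this read-out higher numbers stand for weaker inhibition and lower numbers for stronger inhibition. Among the measured compounds shown here, compound 1 gives 10 nM and compound 2 gives 22.1 nM, so compound 2 stands at the higher of the two numbers; the gap between them is beyond the scatter, though the two differ in more than one place and no single step links them.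

Compound 3 `CCN(c1nc(C)cc(N2CC=C(c3cccc(F)c3)CC2)n1)c1ccc(C(C)C)cc1SC` is not yet measured. It differs from compound 2 in one place: methylsulfanyl in place of bromo on an aromatic carbon. Compound 1, which already carries methylsulfanyl, gives 10 nM, so a move in the same direction is expected, a modest step toward stronger inhibition rather than none. The estimate a 1.8-fold lower number from compound 2 to compound 3 (0.27 log units; within the scatter) rests on that single comparison. Compound 3 is expected at about 12 nM, with a likely range from 5 nM to 30 nM.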

Compound 3, half-maximal inhibitory concentration: 12.7 nM
Compound 3: middle estimate off by 1.1-fold (0.02 log units), on the low side; the range from low to high includes it.
By their numbers in this assay, from the lowest: compounds 1, 3 and 2 (each within the scatter of the next, the first and the last beyond it).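

Methylsulfanyl in place of bromo on an aromatic carbon gives a 1.7-fold lower number from compound 2 to compound 3 (0.24 log units; within the scatter) in this assay and is the first one-place comparison available in the series. At this place, ortho to a large group and meta to an isopropyl group, the two groups are therefore not told apart, although methylsulfanyl brings one more heavy atom and one hydrogen-bond acceptor. No measurement in hand accounts for this result.

Going by these compounds, whether this place accepts groups of other kinds, such as an amine, a carboxylic acid or a longer chain on the sulfur, remains open. Also open, on these data alone, is whether the same exchange would read alike with the other ring substituents of compound 1.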